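A few compounds are considered here, and "the series" means these few. Any claim that something is new, unique, unknown or untested is made for them only; others in the source may bear on it.

Compound 1 `Cc1cc(C2CCC2)c(S(C)(=O)=O)cc1C(=O)N=C(N)N` gives 8.2 nM in a functional assay for inhibition of sodium/hydrogen exchanger (Oryctolagus cuniculus); on this read-out lower numbers stand for stronger inhibition and higher numbers for weaker inhibition.
Compound 2 `Cc1cc(C2CCCCC2)c(S(C)(=O)=O)cc1C(=O)N=C(N)N` gives 22 nM in this assay.
Compound 3 `CCCSc1cc(C)c(C(=O)N=C(N)N)cc1S(C)(=O)=O` gives 6.8 nM in this assay.

Compound 3 has the lowest of the three numbers. Its gap to compound 1, a 1.2-fold lower number from compound 1 to compound 3 (0.08 log units; within the scatter), stays within the scatter, so the two cannot be ordered; its gap to compound 2, a 3.2-fold lower number from compound 2 to compound 3 (0.51 log units; beyond the scatter), is beyond the scatter. The next compound, compound 4 `Cc1cc(OC2CCCC2)c(S(C)(=O)=O)cc1C(=O)N=C(N)N`, changes one place of compound 3: cyclopentyloxy in place of propylsulfanyl on an aromatic carbon. Among the measured compounds shown here, two measured steps bear on this. The step of a 2.7-fold higher number from compound 1 to compound 2 (0.43 log units; beyond the scatter) shows that enlarging the ring at this position costs potency modestly, while the step of a 1.2-fold lower number from compound 1 to compound 3 (0.08 log units; within the scatter) shows that propylsulfanyl and cyclobutyl are not separable. The entering cyclopentyloxy brings a five-membered ring, between the cyclobutyl of compound 1 and the cyclohexyl of compound 2, so a small rise in the number is expected for compound 4, probably near the edge of the scatter, as a 1.8-fold higher number from compound 3 to compound 4 (0.25 log units; within the scatter). Compound 4 is therefore estimated at 12 nM in this assay, with a range from 5 nM to 30 nM.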

Compound 4, half-maximal inhibitory concentration: 27 nM
Estimate against measurement, compound 4: 2.3-fold (0.35 log units) below, within the range that was stated.
By their numbers in this assay, from the lowest: compounds 3 and 1 (each within the scatter of the next); then compounds 2 and 4 (each within the scatter of the next).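

In this assay, the change to cyclopentyloxy carries a real cost against the two lowest compounds: a 4.0-fold higher number from compound 3 to compound 4 (0.60 log units; beyond the scatter) and a 3.3-fold higher number from compound 1 to compound 4 (0.52 log units; beyond the scatter). Ring size alone therefore does not order this position, for the five-membered ring joined through oxygen cannot be told apart from the cyclohexyl group, with a 1.2-fold higher number from compound 2 to compound 4 (0.09 log units; within the scatter). Nothing available explains this result.

The compounds shown change the linking atom and the ring together, so they leave open which of the two goes with the higher number. A propoxy chain or a cyclopentylsulfanyl group at this position would separate the two, while an amine link or a directly attached cyclopentyl group would show whether the pattern extends beyond the oxygen and sulfur links seen here.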